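A few compounds are considered here, and "the series" means these few. Any claim that something is new, unique, unknown or untested is made for them only; others in the source may bear on it.

In a functional assay on HT-29 cells (Homo sapiens) for antiproliferative activity, read by sulforhodamine B assay, with a stated time of 72 h (a lower number here means a stronger inhibitor, a higher number a weaker inhibitor), the measured compounds are:
compound 1 `S=C(N/N=C/c1ccc2ccccc2n1)Nc1ccc(Br)cc1`, 54400 nM
compound 2 `Cc1ccccc1NC(=S)N/N=C/c1ccc2ccccc2n1`, 42300 nM
compound 3 `S=C(NCc1ccccc1)N/N=C/c1ccc2ccccc2n1`, 75700 nM

Compound 1 has the second highest of these three numbers, and both its neighbours lie within the scatter: a 1.3-fold lower number from compound 1 to compound 2 (0.11 log units; within the scatter) and a 1.4-fold higher number from compound 1 to compound 3 (0.14 log units; within the scatter). The remaining step, a 1.8-fold higher number from compound 2 to compound 3 (0.25 log units; within the scatter), is within the scatter as well. All three known steps swap the whole group on the amide-type nitrogen; none alters a substituent on that group's aromatic ring, so none bears directly on the change to compound 4 `FC(F)(F)c1ccc(NC(=S)N/N=C/c2ccc3ccccc3n2)cc1`: trifluoromethyl in place of bromo on an aromatic carbon. Within the data shown here, with every known step within the scatter and no step of this kind measured, compound 4 is expected to show no step beyond the scatter, a 1.1-fold lower number from compound 1 to compound 4 (0.04 log units; within the scatter). Compound 4 is therefore estimated in this assay at 50000 nM, with a range from 22000 nM to 115000 nM.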

Compound 4, half-maximal inhibitory concentration: 63900 nM
Beside the measured number, compound 4's estimate is 1.3-fold (0.11 log units) below it; the range from low to high includes it.
By their numbers in this assay, from the lowest: compounds 2, 1, 4 and 3 (each within the scatter of the next).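

In this assay, among these compounds, this is the one step that changes a substituent on the aromatic ring while the rest of compound 1 stays the same: trifluoromethyl in place of bromo gives a 1.2-fold higher number from compound 1 to compound 4 (0.07 log units; within the scatter). At this place, para to a large group, four heavy atoms can thus replace one and the number stays within the scatter. Nothing measured here offers a reason for this result.

Going by these compounds, whether an amine or a carboxylic acid at this place would give a step beyond the scatter remains open.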